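From Methoxypropyl to a Hydroxymethyl-Bearing Chain

The compounds below may be only part of what the source reports. "The series", "measured", "known", "first", "only" and "open" are said of these compounds alone.

Three compounds have been measured in an assay on isolated protein for inhibition of interferon-induced, double-stranded RNA-activated protein kinase (Homo sapiens), read by luminescence, with a stated time of 10 min; on this read-out higher numbers stand for weaker inhibition and lower numbers for stronger inhibition:
compound 1 `Cc1[nH]c2ccccc2c1-c1ccnc(NCCO)n1`: 11000 nM
compound 2 `Oc1nncc(Nc2ccc3cn[nH]c3c2)n1`: 13000 nM
compound 3 `COCCCNc1nccc(-c2c(C)[nH]c3ccccc23)n1`: 1500 nM

Among the measured compounds shown here, compound 3 stands lowest of the three numbers; the single measured step that reaches it, a 7.3-fold lower number from compound 1 to compound 3 (0.87 log units; beyond the scatter), lies beyond the scatter, and the gap to compound 2 is larger still.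

Compound 4 `Cc1[nH]c2ccccc2c1-c1ccnc(NC(CO)C(C)C)n1` is not yet measured. It differs from compound 3 by 1-(hydroxymethyl)-2-methylpropyl in place of 3-methoxypropyl on a nitrogen on an aromatic ring. For the measured compounds named here, the one step that bears on this is a 7.3-fold lower number from compound 1 to compound 3 (0.87 log units; beyond the scatter), which ran from a hydroxy-bearing chain to a methoxy-bearing one; compound 4 brings a hydroxy back, now in the 1-(hydroxymethyl)-2-methylpropyl group. A number between those of compound 1 and compound 3 is therefore expected. Compound 4 is estimated at 3500 nM, range 1000 nM to 12000 nM, an expected step of a 2.3-fold higher number from compound 3 to compound 4 (0.37 log units; beyond the scatter) in this assay.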

Compound 4, half-maximal inhibitory concentration: 50000 nM
For compound 4 the middle estimate is 14-fold (1.15 log units) below the measured one, outside the stated range (above it).
By their numbers in this assay, from the lowest: compound 3; then compounds 1 and 2 (each within the scatter of the next); then compound 4.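

Among the compounds shown here, the chain on the nitrogen tolerates this change far less well than the earlier compounds hinted: 1-(hydroxymethyl)-2-methylpropyl in place of 3-methoxypropyl gives a 33-fold higher number from compound 3 to compound 4 (1.52 log units; beyond the scatter), a larger step than any seen before. Within the hydroxy-bearing chains, isopropyl in place of hydrogen on the chain carbon bound to the nitrogen also counts against inhibition, with a 4.5-fold higher number from compound 1 to compound 4 (0.66 log units; beyond the scatter). Nothing on hand explains either step.

The compounds shown leave open how a methoxy-bearing chain with the same isopropyl would read. On these data alone, an amine or a carboxylic acid in place of the hydroxy is equally open.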